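Trifluoromethyl for chloro in a series near its limit

The compounds below may be only part of what the source reports. "The series", "measured", "known", "first", "only" and "open" are said of these compounds alone.

In a functional assay on HCT-116 cells (Homo sapiens) for cytotoxicity, read by MTT assay (on this read-out lower numbers stand for stronger inhibition and higher numbers for weaker inhibition), compound 3 `Cc1cc(O)c(C(=O)/C=C/c2ccccc2Cl)c(=O)o1` gives only a limit, > 100000 nM. Compound 1 `Cc1cc(O)c(C(=O)/C=C/c2ccccc2F)c(=O)o1` likewise gives only a limit, > 100000 nM. Compound 2 `Cc1cc(O)c(C(=O)/C=C/c2ccc(Cl)cc2Cl)c(=O)o1` gives a number, 88700 nM. The series is thus marked by the limit of > 100000 nM in this assay, at which 2 of the 3 values shown sit. Compound 4 `Cc1cc(O)c(C(=O)/C=C/c2ccccc2C(F)(F)F)c(=O)o1` carries trifluoromethyl in place of chloro on an aromatic carbon, ortho to a large group (trifluoromethyl in place of chloro on an aromatic carbon). Among the compounds with values here, two measured steps bear on this change: a step that the two limits leave unreadable from compound 1 to compound 3, and an at least 1.1-fold higher number from compound 2 to compound 3 (0.05 log units; that floor lies within the scatter). Neither shows a readable effect at this place, so no step beyond the scatter is expected in this assay, and another limit is quite possible. The expected step is a number no higher from compound 3 to compound 4 (the limit leaves the size open). The estimated value for compound 4 is 100000 nM, with an expected range of 60000 nM to 200000 nM.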

Compound 4, half-maximal inhibitory concentration: > 100000 nM
Compound 4: no number, only a limit; the forecaster's own chance of this, stated with the estimate: 75%; the middle value lies on the limit itself.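

Compound 4 joins compound 1 and compound 3 at a limit, so no new step can be read among them: the limit of > 100000 nM in this assay, at which 3 of the 4 values shown sit. From the compounds shown here alone, whether fluoro, chloro and trifluoromethyl at this place differ at all in this assay stays open.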